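Replacing one nitro group with a tert-butoxycarbonyl group

The compounds below may be only part of what the source reports. "The series", "measured", "known", "first", "only" and "open" are said of these compounds alone.

In a functional assay on QG-56 cells (Homo sapiens) for antiproliferative activity (a higher number here means a weaker inhibitor, a lower number a stronger inhibitor), compound 1 (`Cn1cncc1C(O)(c1ccc([N+](=O)[O-])cc1)c1cc2cc([N+](=O)[O-])cc(-c3ccccc3)c2o1`) gives 547 nM. Compound 2 (`Cn1cncc1C(O)(c1ccc(C#N)cc1)c1cc2cc(C#N)cc(-c3ccccc3)c2o1`) gives 14.5 nM, which leaves compound 1 with the higher number of the two and so the weaker inhibitor, by more than the usual scatter. Compound 3 (`Cn1cncc1C(O)(c1ccc(C(=O)OC(C)(C)C)cc1)c1cc2cc([N+](=O)[O-])cc(-c3ccccc3)c2o1`) has not yet been measured. It keeps the rest of compound 1 but carries tert-butoxycarbonyl in place of nitro on an aromatic carbon, para to a large group: tert-butoxycarbonyl in place of nitro on an aromatic carbon. Among the compounds with values here, no two measured compounds differ in one place only, so the data offer no direct guide to this swap. For that reason the expectation is cautious, and no shift beyond the scatter is expected in this assay: the estimated change is a 1.3-fold higher number from compound 1 to compound 3 (0.11 log units; within the scatter). For compound 3 the estimated value is 700 nM, with an expected range from 150 nM to 2500 nM.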

Compound 3, half-maximal inhibitory concentration: 6250 nM
Compound 3: middle estimate off by 8.9-fold (0.95 log units), on the low side; the whole stated range lies below it.
By their numbers in this assay, from the lowest: compound 2; then compound 1; then compound 3.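

In this assay, this place on the aromatic ring, para to a large group, proves sensitive to its substituent: tert-butoxycarbonyl in place of nitro gives an 11-fold higher number from compound 1 to compound 3 (1.06 log units; beyond the scatter) and so a clearly weaker inhibitor. The two groups have the same counts of hydrogen-bond donors and acceptors, the same single double bond outside aromatic rings and no net charge, though tert-butoxycarbonyl has 7 heavy atoms against 3 for nitro, so those matching counts do not keep the activity level. No measurement here explains the loss.

Going by these compounds, it remains open whether the loss follows from the tert-butyl part or from the ester as a whole. A methyl ester or a carboxylic acid at this place would help tell those two apart.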